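Adding a Methoxy Group to the Phenyl Ring of Compound 2

This account rests on a few compounds, and the source may have more. Where it says the series, first, only, none or still open, it means among the compounds named here.

Compound 1 `Nc1cccc(-c2cn3nc(Cc4ccccc4)sc3n2)c1` gives 24000 nM
Compound 2 `C=C(Br)C(=O)Nc1cccc(-c2cn3c(-c4ccccc4)csc3n2)c1` gives 3400 nM

Both numbers come from a functional assay on HeLa cells (Homo sapiens) for inhibition, read by cell counting, with a stated time of 4 days (on this read-out higher numbers stand for weaker inhibition and lower numbers for stronger inhibition), where a smaller concentration marks a stronger effect on cell growth. Compound 2 stands at the lower of the two numbers, and compound 1 lies beyond the usual scatter above it, so compound 2 is the stronger inhibitor of the pair. The two compounds differ in more than one place, so their values say nothing about any single change.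

Compound 3 `C=C(Br)C(=O)Nc1cccc(-c2cn3c(-c4ccc(OC)cc4)csc3n2)c1` is not yet measured. It differs from compound 2 by one change: methoxy in place of hydrogen on an aromatic carbon. Read one bond further out, this is phenyl becoming 4-methoxyphenyl. Among the compounds with values here, no measured pair in this set shows the effect of such a change, so there is no direct guide. A small step in either direction, or none beyond the scatter, is expected for this assay.

Compound 3 is therefore estimated to give about 2500 nM, within a range from 800 nM to 8000 nM. This estimate means an expected step of a 1.4-fold lower number from compound 2 to compound 3 (0.13 log units; within the scatter).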

Compound 3, half-maximal inhibitory concentration: 860 nM
Compound 3: middle estimate off by 2.9-fold (0.46 log units), on the high side; the range from low to high includes it.
By their numbers in this assay, from the lowest: compound 3; then compound 2; then compound 1.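

Putting methoxy in place of hydrogen on an aromatic carbon of the phenyl ring, para to a large group, gives a 4.0-fold lower number from compound 2 to compound 3 (0.60 log units; beyond the scatter) in this assay and counts as a modest step beyond the usual scatter. Within the data shown here, this is the first change here that can be read on its own, since compound 1 differs from the others in more than one place, and it shows that this position accepts a group of 2 heavy atoms with a stronger inhibition of cell growth as the result. Nothing on hand explains the drop in the number, so the step stands as an observation with no cause attached.

One substituent at one position cannot show how much of the step comes from the oxygen and how much from the methyl part, and a hydroxyl group, a fluorine atom, an amine or the longer ethoxy chain on the same carbon would help to separate these. On these data alone, it also remains open whether methoxy would give a similar step on another carbon of this ring, or on a compound with a different group in place of the bromoacrylamide.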